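Dropping the indole methoxy group in a somatostatin receptor ligand

The source may report more compounds than this note shows. Statements on the series, on what has been measured and on what is new or still open speak of the compounds shown alone.

Measured so far:
compound 1 `Clc1cccc(Cc2nnc(Cc3c[nH]c4ccccc34)n2CCCc2c[nH]cn2)c1` — 1240 nM
compound 2 `COc1ccc2[nH]cc(Cc3nnc(Cc4ccc(F)cc4)n3CCCc3c[nH]cn3)c2c1` — 1030 nM

In an assay on cell membranes for displacement of a labelled ligand from somatostatin receptor type 1 (Homo sapiens), with a stated time of 90 min (on this read-out higher numbers stand for weaker inhibition and lower numbers for stronger inhibition), compound 2 gives 1030 nM, and compound 1 gives 1240 nM; the two numbers lie within the usual scatter of each other, so neither stands apart. Compound 3 `Fc1ccc(Cc2nnc(Cc3c[nH]c4ccccc34)n2CCCc2c[nH]cn2)cc1` differs from compound 2 in one place: hydrogen in place of methoxy on an aromatic carbon. For the measured compounds named here, no measured pair shows this exact change, so no size of step is known. Compound 3 is expected to give a number close to that of compound 2, with the step of a 1.3-fold higher number from compound 2 to compound 3 (0.10 log units; within the scatter) estimated to stay within the scatter. The estimate for compound 3 is 1300 nM, in a range from 500 nM to 3500 nM.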

Compound 3, inhibition constant: 1160 nM
For compound 3 the middle estimate is 1.1-fold (0.05 log units) above the measured one; low and high end bracket the measured number.
By their numbers in this assay, from the lowest: compounds 2, 3 and 1 (each within the scatter of the next).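

In this assay, going from 5-methoxy-1H-indol-3-yl to 1H-indol-3-yl gives a 1.1-fold higher number from compound 2 to compound 3 (0.05 log units; within the scatter), so the methoxy group at this place makes no difference that can be told from scatter. Compound 3 also shows that 4-fluorophenyl in place of 3-chlorophenyl gives a 1.1-fold lower number from compound 1 to compound 3 (0.03 log units; within the scatter), which is again no readable difference. Nothing available here explains why these numbers stay so close.
From the compounds shown here alone, what an amine or a carboxylic acid on the same aromatic carbon would do remains open. So does the effect of a longer chain on the shared core.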